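Replacing the Amine of Compound 1 with a Hydroxyl

The compounds below may be only part of what the source reports. "The series", "measured", "known", "first", "only" and "open" are said of these compounds alone.

Compound 1 `CC(C)NCc1ccc(-c2c3ncn(CC4(O)CCN(Cc5ccc(-c6ccco6)cc5Cl)CC4)c(=O)c3nn2C)cc1`: 29.1 nM
Compound 2 `Cn1nc2c(=O)n(CC3(O)CCN(Cc4ccc(C5CCCO5)cc4Cl)CC3)cnc2c1-c1ccc(CN)cc1`: 3820 nM
Compound 3 `Cn1nc2c(=O)n(CC3(O)CCN(Cc4ccc(-c5ccc[nH]5)cc4Cl)CC3)cnc2c1-c1ccc(CN)cc1`: 193 nM

Among these three, compound 1 gives the lowest number in an assay on isolated protein for inhibition of ubiquitin carboxyl-terminal hydrolase 7 (Homo sapiens), with stated times of 30 min and 2 h; on this read-out lower numbers stand for stronger inhibition and higher numbers for weaker inhibition; compound 3 stands nearest to it and compound 2 furthest. Among the compounds with values here, the only step between compounds differing in one place, a 20-fold lower number from compound 2 to compound 3 (1.30 log units; beyond the scatter), concerns a different group and does not touch the change considered here. Compound 4 `Cn1nc2c(=O)n(CC3(O)CCN(Cc4ccc(-c5ccco5)cc4Cl)CC3)cnc2c1-c1ccc(CO)cc1` differs from compound 1 by hydroxy in place of isopropylamino on a saturated chain carbon bound to an aromatic carbon. Within the data shown here, no measured step bears on this change, so the expectation rests on the three values alone and carries wide uncertainty. A weaker inhibition is expected from this change, a step of a 5.2-fold higher number from compound 1 to compound 4 (0.71 log units; beyond the scatter). Compound 4 is therefore estimated to give 150 nM, within a range from 40 nM to 600 nM.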

Compound 4, half-maximal inhibitory concentration: 42.5 nM
For compound 4 the middle estimate is 3.5-fold (0.55 log units) above the measured one; the range from low to high includes it.
By their numbers in this assay, from the lowest: compounds 1 and 4 (each within the scatter of the next); then compound 3; then compound 2.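

In this assay, hydroxy in place of isopropylamino gives a 1.5-fold higher number from compound 1 to compound 4 (0.16 log units; within the scatter) and so leaves the two compounds indistinguishable. Within the data shown here, for this pair, then, a group of 4 heavy atoms containing nitrogen and a single oxygen atom serve equally well on this saturated chain carbon bound to an aromatic carbon, something the earlier compounds could not show. No measurement shown here explains why the two groups read alike. Going by these compounds, whether a methoxy group or a carboxylic acid on the same carbon would also hold this level remains open.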